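Fluorine Pattern on the Phenyl Ring: Compound 1 to Compound 4

A few compounds are considered here, and "the series" means these few. Any claim that something is new, unique, unknown or untested is made for them only; others in the source may bear on it.

The measured compounds and their numbers:
compound 1, `COc1cc2c(Oc3ccc(NC(=O)NN4C(=O)CSC4c4ccc(F)cc4)cc3)ccnc2cc1OC1CCN(C(=O)NC(C)C)CC1`, gives 860 nM in a functional assay on HT-29 cells (Homo sapiens) for inhibition, read by MTT assay; on this read-out higher numbers stand for weaker inhibition and lower numbers for stronger inhibition;
compound 2, `COc1cc2c(Oc3ccc(NC(=O)NN4C(=O)CSC4c4ccc(F)c(F)c4)cc3)ccnc2cc1OC1CCN(C(=O)NC(C)C)CC1`, gives 1060 nM in this assay;
compound 3, `COc1cc2c(Oc3ccc(NC(=O)NN4C(=O)CSC4c4cccc(F)c4F)cc3)ccnc2cc1OC1CCN(C(=O)NC(C)C)CC1`, gives 790 nM in this assay.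

Compound 1 sits between its two neighbours, with a 1.1-fold lower number from compound 1 to compound 3 (0.04 log units; within the scatter) and a 1.2-fold higher number from compound 1 to compound 2 (0.09 log units; within the scatter); neither gap leaves the scatter. Compound 4, `COc1cc2c(Oc3ccc(NC(=O)NN4C(=O)CSC4c4c(F)cccc4F)cc3)ccnc2cc1OC1CCN(C(=O)NC(C)C)CC1`, differs from compound 1 by 2,6-difluorophenyl in place of 4-fluorophenyl on a saturated ring carbon. For the measured compounds named here, three measured steps bear on this change, all of them on the same phenyl ring: a 1.2-fold higher number from compound 1 to compound 2 (0.09 log units; within the scatter), a 1.1-fold lower number from compound 1 to compound 3 (0.04 log units; within the scatter) and a 1.3-fold lower number from compound 2 to compound 3 (0.13 log units; within the scatter). Each of these rearranges or adds fluorine on that ring, and each stays within the scatter. Going by the values given here, no measured step shows a 2,6-difluorophenyl, so the expectation rests on the three steps alone. On that basis no step beyond the scatter is expected in this assay, in either direction. Compound 4 is expected to give about 900 nM, in the range 450 nM to 1800 nM. The expected step is then a 1.0-fold higher number from compound 1 to compound 4 (0.02 log units; within the scatter).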

Compound 4, half-maximal inhibitory concentration: 310 nM
Beside the measured number, compound 4's estimate is 2.9-fold (0.46 log units) above it; the measured number lies below the stated range.
By their numbers in this assay, from the lowest: compound 4; then compounds 3, 1 and 2 (each within the scatter of the next).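

In this assay, the fluorine pattern on this phenyl ring proves able to move the result: 2,6-difluorophenyl gives a 2.8-fold lower number from compound 1 to compound 4 (0.44 log units; beyond the scatter), a 2.5-fold lower number from compound 3 to compound 4 (0.41 log units; beyond the scatter) and a 3.4-fold lower number from compound 2 to compound 4 (0.53 log units; beyond the scatter). The number of fluorines alone does not separate these compounds, as compound 2 and compound 3 also carry two fluorines yet stay within the scatter of compound 1, so the change tracks this particular pattern among the four compounds. Nothing available here explains why this pattern stands apart.

On these data alone, it remains open whether the step depends on fluorine itself, or whether chlorine or methyl in place of the two fluorines of the 2,6-difluorophenyl would give a similar number. The compounds shown also leave open whether this step carries over to any other assay.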